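The source may hold more compounds than are shown below. What is called first, only, known or untested is meant among the compounds shown, and "the series" means these compounds.

Measured compounds and their values:

- Compound 1, `COc1cc(-n2cnc3ccc(-c4cccc(N)c4)cc32)cc(OC)c1OC`, gives 640 nM in a functional assay on A549 cells (Homo sapiens) for antiproliferative activity, read by MTT assay, with a stated time of 72 h; a lower number here means a stronger inhibitor, a higher number a weaker inhibitor.
- Compound 2, `COc1cc(-n2cnc3ccc(-c4ccc([N+](=O)[O-])cc4)cc32)cc(OC)c1OC`, gives 8940 nM.
- Compound 3, `COc1cc(-n2cnc3ccc(-c4ccc(C(F)(F)F)cc4)cc32)cc(OC)c1OC`, gives 3390 nM.

Compound 2 stands highest of these three numbers, which here means the weakest inhibitor. Its nearest neighbour is compound 3, reached by a 2.6-fold lower number from compound 2 to compound 3 (0.42 log units; beyond the scatter), and its furthest is compound 1, reached by a 14-fold higher number from compound 1 to compound 2 (1.15 log units; beyond the scatter). The new compound 4, `COc1cc(-n2cnc3ccc(-c4ccc(C)cc4F)cc32)cc(OC)c1OC`, differs from compound 2 at the same position: 2-fluoro-4-methylphenyl in place of 4-nitrophenyl on an aromatic carbon. Among the compounds with values here, the step that bears most directly on this change is the one from compound 2 to compound 3, where replacing the nitro by a group without hydrogen-bond acceptors already gave a 2.6-fold lower number from compound 2 to compound 3 (0.42 log units; beyond the scatter). The step of a 5.3-fold higher number from compound 1 to compound 3 (0.72 log units; beyond the scatter) shows that such groups still sit well above compound 1. A lower number is therefore expected from compound 2 to compound 4, roughly a 3.6-fold lower number from compound 2 to compound 4 (0.55 log units; beyond the scatter), of a size comparable to the move to compound 3. Compound 4 is estimated at 2500 nM, within a range from 800 nM to 8000 nM.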

Compound 4, half-maximal inhibitory concentration: > 10000 nM
Compound 4: only a limit was reported; the forecaster's own chance of this, stated with the estimate: 5%; at least 4.0-fold (0.60 log units) between middle value and limit.
By their numbers in this assay, from the lowest: compound 1; then compound 3; then compound 2. At a limit, above all of these: compound 4.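

In this assay compound 4 reaches only a limit of the assay, not a number: the limit of > 10000 nM in this assay, at which 1 of the 4 values shown sits. Placing 2-fluoro-4-methylphenyl at this position gives an at least 1.1-fold higher number from compound 2 to compound 4 (0.04 log units; that floor lies within the scatter), so removing the nitro group does not by itself bring a gain here, although the order of these two compounds stays unsettled. The other two steps, an at least 2.9-fold higher number from compound 3 to compound 4 (0.46 log units; beyond the scatter) and an at least 15-fold higher number from compound 1 to compound 4 (1.19 log units; beyond the scatter), show that not every nitro-free phenyl group matches 4-(trifluoromethyl)phenyl, and that 3-aminophenyl keeps a wide lead over this new group.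

Only one amine-bearing phenyl group appears among these compounds, so it remains unclear whether the amine itself accounts for the lead of compound 1. From the compounds shown here alone, how a hydroxyl or a carboxylic acid on that phenyl ring would compare also remains open.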